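The source may report more compounds than this note shows. Statements on the series, on what has been measured and on what is new or still open speak of the compounds shown alone.

Among the measured compounds shown here, compound 2 `O=C(Nc1cccc(Br)c1)C(Cl)Cl` is the only one of the pair with a number in a functional assay on Bel-7402 cells (Homo sapiens) for antiproliferative activity, read by MTT assay, with a stated time of 72 h; a lower number here means a stronger inhibitor, a higher number a weaker inhibitor: in this assay compound 2 gives 7720 nM. Its companion, compound 1 `O=C(Nc1ccccc1Cl)C(Cl)Cl`, carries a dichloroacetamide as well, but in this assay compound 1 gives "not determined" (no result reported), so compound 2 stands alone on the numbers shown and no step between measured compounds can be drawn from it.

Compound 3 `COc1cccc(NC(=O)C(Cl)Cl)c1` differs from compound 2 in one place: methoxy in place of bromo on an aromatic carbon. For the measured compounds named here, with no measured step of this kind to lean on, the change from a halogen to a methoxy in the same place gives little ground for expecting a shift beyond the scatter in this assay, in either direction.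

Compound 3 is therefore expected to sit near compound 2, with an estimated step of a 1.2-fold higher number from compound 2 to compound 3 (0.07 log units; within the scatter). In this assay compound 3 is estimated at 9000 nM, within a range from 3000 nM to 27000 nM.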

Compound 3, half-maximal inhibitory concentration: 54800 nM
Estimate against measurement, compound 3: 6.1-fold (0.78 log units) below; the measured number lies above the stated range.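

Among the compounds shown here, the only step available between measured compounds shows that this aromatic carbon, meta to a group of 6 heavy atoms, is not indifferent to the group it carries: in this assay, methoxy in place of bromo gives a 7.1-fold higher number from compound 2 to compound 3 (0.85 log units; beyond the scatter). This step lies beyond the scatter, so here the exchange of bromo for methoxy goes with a clearly weaker inhibitor, and the two groups cannot be treated as interchangeable at this place. No measurement at hand bears on why the number rises.

The compounds shown leave open whether this loss belongs to methoxy in particular or would also appear with an amine, a hydroxyl or a longer chain such as ethoxy at the same place. They also leave open whether chloro or iodo would stay close to compound 2 in this assay.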